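The compounds below may be only part of what the source reports. "The series", "measured", "known", "first", "only" and "open" are said of these compounds alone.

Measured so far in a physicochemical assay for solubility, at pH 1.1; a higher number here means a more soluble compound, a lower number a less soluble compound:
- compound 1 `CCCN(Cc1ccc(OCCN2C(=O)CCC2=O)c(OC)c1)C(C(=O)O)c1ccc(Cl)cc1` gives 3000000 nM
- compound 2 `CCCN(Cc1ccc(OCCN2C(=O)CCC2=O)c(C)c1)C1c2ccc(Cl)cc2CC1C(=O)O` gives 3000000 nM
- compound 3 `CCCN(Cc1ccc(OCCN2C(=O)CCC2=O)c(C)c1)C(CC(=O)O)c1ccc(Cl)cc1` gives 3000000 nM

Compound 3 stands level with compound 1 and compound 2, with no gap among the three at the digits reported. Compound 4 `CCCN(Cc1ccc(OCCN2C(=O)CCC2=O)c(C)c1)[C@@H](CC(=O)O)c1ccc(Cl)cc1` is closely related to compound 3: the two compounds have the same atoms and bonds; at least one stereo element is drawn with a configuration in one of them and without one in the other: 1 of 1 stereo elements differ; a stereocentre at a saturated chain carbon is drawn without a configuration in compound 3 and S in compound 4 and nothing else, so the two compounds have the same atoms and bonds. Going by the values given here, no two measured compounds differ in only one place, so the data offer no direct guide to this change. In this assay no step beyond the scatter is expected, in either direction. This expectation rests on compound 3 at 3000000 nM and on its two measured relatives matching it. The estimated step of no change at the digits printed from compound 3 to compound 4 (within the scatter) should therefore stay within the scatter. For compound 4 the expected value is 3000000 nM with an estimated range of 1500000 nM to 4000000 nM in this measurement.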

Compound 4, solubility: 3000000 nM
Beside the measured number, compound 4's estimate shows no gap at the digits printed, within the range that was stated.
By their numbers in this assay, from the lowest: compounds 1, 2, 3 and 4 (each within the scatter of the next).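

In this assay, going by these compounds alone, the first comparison of two compounds that differ in one place gives no change at the digits printed from compound 3 to compound 4 (within the scatter). At this saturated chain carbon, then, drawing the stereocentre as S rather than without a configuration leaves the reading level. The pair differs only in how this one centre is drawn: the fact that one of compounds 3 and 4 is drawn with a defined configuration and the other without, at the place where they differ

The compounds shown leave open whether the R configuration at this carbon would read the same. They also leave open whether a primary amide in place of the carboxylic acid would stay level in this assay.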